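Swapping a Long Nitrogen-Bearing Side Chain for Hydroxy

The source may hold more compounds than are shown below. What is called first, only, known or untested is meant among the compounds shown, and "the series" means these compounds.

Compound 1 `N=C(N)NCCC[C@H](NC(=O)CN(c1nc(Cl)nc2c1ncn2C1CCCCO1)C1CC1)C(=O)OCc1ccccc1` is the reference point. Within the data shown here, in a functional assay on the whole organism with Mus musculus as the target, with a stated time of 90 min, at a dose of 25 umol/kg by the oral route (on this read-out lower numbers stand for a weaker effect and higher numbers for a stronger effect at the one dose given), compound 1 gives 61.6%, the highest of the three numbers measured so far. Compound 2 `NC(=O)CC[C@H](NC(=O)CN(c1nc(Cl)nc2c1ncn2C1CCCCO1)C1CC1)C(=O)OCc1ccccc1` gives 37.8%, and compound 3 `CC(C)C[C@H](NC(=O)CN(c1nc(Cl)nc2c1ncn2C1CCCCO1)C1CC1)C(=O)OCc1ccccc1` gives 28.2%. Compound 4 `O=C(CN(c1nc(Cl)nc2c1ncn2C1CCCCO1)C1CC1)N[C@@H](CO)C(=O)OCc1ccccc1` differs from compound 1 in a single place: one oxygen atom in place of a group of 6 heavy atoms (3 carbon, 3 nitrogen; no ring), on a saturated chain carbon, two bonds along the chain from an amide-type nitrogen and a carbonyl carbon. Among the measured compounds shown here, two measured steps bear on this change, a number 23.8 percentage points lower from compound 1 to compound 2 (beyond the scatter) and a number 33.4 percentage points lower from compound 1 to compound 3 (beyond the scatter), each exchanging the large nitrogen-bearing side chain of compound 1 for a smaller group, and each lowering the read-out. A drop of comparable size is therefore expected for the smaller hydroxy group, namely a number 29.6 percentage points lower from compound 1 to compound 4 (beyond the scatter). Compound 4 is estimated at 32%, with a range from 15% to 50%.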

Compound 4, a percentage reported as activity, at one dose (the size of the read-out at that dose, not a potency): 32.2%
The estimate for compound 4 lay 0.2 percentage points below the measured number, and the stated range covers the measured number.
By their numbers in this assay, from the lowest: compounds 3, 4 and 2 (each within the scatter of the next); then compound 1.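

Even a lone hydroxy, a single heavy atom, lands with the other small groups: (a number 29.4 percentage points lower from compound 1 to compound 4 (beyond the scatter)). Hydroxy, isopropyl and carbamoylmethyl cannot be told apart at this carbon, since both remaining steps stay within the scatter (a number 4 percentage points higher from compound 3 to compound 4 (within the scatter); a number 5.6 percentage points lower from compound 2 to compound 4 (within the scatter)), so the size of the smaller group makes no readable difference here. Nothing measured here accounts for compound 1 standing apart.

Still open, on these data alone, is whether a primary amine or a carboxylic acid on a longer chain at this carbon would match compound 1 or fall with the smaller groups.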